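Carbonyl variants in the platelet read-out: ester to amide

The compounds below may be only part of what the source reports. "The series", "measured", "known", "first", "only" and "open" are said of these compounds alone.

Measured in a functional assay on cells (Platelet, Homo sapiens) for inhibition (a higher number here means a weaker inhibitor, a lower number a stronger inhibitor), each value a limit and not a number:
- compound 1 `O=C(O)c1ccc(-c2nn(Cc3ccccc3)c3ccccc23)cc1`: > 10000 nM
- compound 2 `COC(=O)c1ccc(-c2nn(Cc3ccccc3)c3ccccc23)cc1`: > 10000 nM
- compound 3 `CC(C)OC(=O)c1ccc(-c2nn(Cc3ccccc3)c3ccccc23)cc1`: > 10000 nM

Compound 3 gives > 10000 nM, which is a limit of the assay. It has no rank within the series, which so far offers only (the limit of > 10000 nM in this assay, at which 3 of the 3 values shown sit).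

The next structure is compound 4 `NC(=O)c1ccc(-c2nn(Cc3ccccc3)c3ccccc23)cc1`, still unmeasured. It has amino in place of isopropoxy on a carbonyl carbon, so isopropoxycarbonyl becomes carbamoyl (amino in place of isopropoxy on a carbonyl carbon).

Going by the values given here, three measured steps bear on this change: a step that the two limits leave unreadable from compound 1 to compound 2, a step that the two limits leave unreadable from compound 1 to compound 3 and a step that the two limits leave unreadable from compound 2 to compound 3. Among the compounds with values here, none of them has a readable size, and no measured compound carries amino on this carbonyl carbon. They therefore give no direction for the change and no ground for expecting a clear step in this assay. The likeliest outcome is another limit, with a measurable weak value as the less likely alternative.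

The expected size of the change is a step that the limit leaves unreadable from compound 3 to compound 4.

For compound 4 the estimated value is 15000 nM, with an expected range of 4000 nM to 50000 nM.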

Compound 4, half-maximal inhibitory concentration: > 10000 nM
Compound 4: only a limit was reported (the forecaster's own chance of this, stated with the estimate: 75%); the middle value does not contradict the limit.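

In this assay compound 4 gives > 10000 nM, a limit and not a number, so its steps from compound 1, compound 2 and compound 3 cannot be read: the limit of > 10000 nM in this assay, at which 4 of the 4 values shown sit.

The compounds shown leave open whether any group on this carbonyl carbon gives a measurable value in this assay, and how far each compound lies beyond the limit.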